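The compounds below may be only part of what the source reports. "The series", "measured", "known", "first", "only" and "open" are said of these compounds alone.

In a functional assay on HCT-116 cells (Homo sapiens) for cytotoxicity, read by MTT assay, with a stated time of 72 h (on this read-out lower numbers stand for stronger inhibition and higher numbers for weaker inhibition), the three measured compounds give the following numbers:

compound 1, `[O-][S+](CCCCN=C=S)Cc1ccccc1`: 3660 nM
compound 2, `[O-][S+](CCCCCN=C=S)Cc1ccccc1`: 5190 nM
compound 3, `CC(C)[S+]([O-])CCCCCN=C=S`: 3420 nM

Compound 4, `CC(C)[S+]([O-])CCCCCCN=C=S`, has not yet been measured in this assay. Compound 2 is obtained from compound 1 by a single change, (a group of 4 heavy atoms (2 carbon, 1 nitrogen, 1 sulfur; no ring) in place of a group of 3 heavy atoms (1 carbon, 1 nitrogen, 1 sulfur; no ring), on a saturated chain carbon, four bonds along the chain from a sulfur). On that pair the change gave a 1.4-fold higher number from compound 1 to compound 2 (0.15 log units; within the scatter), so the number stayed essentially where it was. Compound 4 is obtained from compound 3 by the change (a group of 4 heavy atoms (2 carbon, 1 nitrogen, 1 sulfur; no ring) in place of a group of 3 heavy atoms (1 carbon, 1 nitrogen, 1 sulfur; no ring), on a saturated chain carbon, five bonds along the chain from a sulfur). This is the same kind of change, not the same change: in compound 1 it sits four bonds along the chain from a sulfur, whereas in compound 3 it sits five bonds along the chain from a sulfur, and the difference between the two cores is not broken down here. For the measured compounds named here, the three measured numbers in this assay lie within the usual scatter of one another, and the only measured step of this kind is itself within the scatter. On that basis the expected step for the new pair is a 1.3-fold higher number from compound 3 to compound 4 (0.12 log units; within the scatter), resting on the measured step of a 1.4-fold higher number from compound 1 to compound 2 (0.15 log units; within the scatter). For compound 4 the estimated number is 4500 nM, with a likely range from 2500 nM to 8500 nM.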

Compound 4, half-maximal inhibitory concentration: 9460 nM
Beside the measured number, compound 4's estimate is 2.1-fold (0.32 log units) below it, outside the stated range (above it).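

On the core of compound 3, in this assay, a group of 4 heavy atoms in place of a group of 3 heavy atoms, on a saturated chain carbon, five bonds along the chain from a sulfur, gave a 2.8-fold higher number from compound 3 to compound 4 (0.44 log units; beyond the scatter), a modest step. The earlier step on the core of compound 1 stayed within the scatter and this one goes beyond it, yet the gap between the two is itself no larger than the scatter of two such steps allows: the same change on two cores in this assay, a 1.4-fold higher number (0.15 log units; within the scatter) from compound 1 to compound 2 and a 2.8-fold higher number (0.44 log units; beyond the scatter) from compound 3 to compound 4, 2.0-fold (0.29 log units) apart, within the scatter of two such steps This shows that the two cores cannot be told apart on this change, which fits a change that carries from one core to the other, but two pairs cannot show that its size is truly the same, nor whether the core or the place, four bonds or five along the chain from a sulfur, has any bearing on the outcome.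

The compounds shown leave open how a longer chain would read on either core. They also leave open what an amine or a carboxylic acid at the end of the chain would do in this assay.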